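Chloro on the anilino ring: one change, two pairs

The source may hold more compounds than are shown below. What is called first, only, known or untested is meant among the compounds shown, and "the series" means these compounds.

Measured in a functional assay on HCT-116 cells (Homo sapiens) for antiproliferative activity, read by CCK-8 assay, with a stated time of 72 h, tested at 2 uM; a lower number here means a weaker effect, a higher number a stronger effect of the compound at the concentration tested:
compound 1, `Nc1ccccc1NC(=O)/C=C/c1ccc(Cn2cnc3c(Nc4cccc(Cl)c4)nc(Cl)nc32)cc1`: 12.9%
compound 2, `CCCCn1cnc2c(Nc3ccccc3)nc(NCOCc3ccc(C(=O)Nc4ccccc4N)cc3)nc21`: 72.9%
compound 3, `Nc1ccccc1NC(=O)/C=C/c1ccc(Cn2cnc3c(Nc4ccccc4)nc(Cl)nc32)cc1`: 7.75%

Compound 2 stands highest of the three, and its gaps to compound 1 and compound 3 are both beyond the scatter. The difference between the core of compound 2 and the core of compound 3 is not broken down here. Within the core of compound 3, the change chloro in place of hydrogen on an aromatic carbon gives a number 5.2 percentage points higher from compound 3 to compound 1 (within the scatter).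

Compound 4, `CCCCn1cnc2c(Nc3cccc(Cl)c3)nc(NCOCc3ccc(C(=O)Nc4ccccc4N)cc3)nc21`, has not been measured. It differs from compound 2 by chloro in place of hydrogen on an aromatic carbon, the same change as from compound 3 to compound 1, at a place described in the same words. The step of a number 2.1 percentage points higher from compound 2 to compound 4 (within the scatter) is expected to be of similar small size, resting on a number 5.2 percentage points higher from compound 3 to compound 1 (within the scatter). Compound 4 is therefore estimated at 75%, between 60% and 88%.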

Compound 4, a percentage reported as inhibition, at one concentration (the size of the read-out at that concentration, not a potency): 58.9%
Beside the measured number, compound 4's estimate is 16.1 percentage points above it; measured number below the stated range.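

In this assay, chloro in place of hydrogen on an aromatic carbon gives a number 14 percentage points lower from compound 2 to compound 4 (beyond the scatter), and this step does not match the one on the other core: the same change on two cores in this assay, a number 5.2 percentage points higher (within the scatter) from compound 3 to compound 1 and a number 14 percentage points lower (beyond the scatter) from compound 2 to compound 4, 19.2 percentage points apart, beyond the scatter of two such steps

Within this series, the step read on the core of compound 3 therefore does not carry over in size or direction to the core of compound 2. The cores differ in more than one place, and these two pairs cannot show which difference goes with the gap, or how the change would behave on any further core.

Open, on these data alone, is whether fluoro, methoxy or an amine on the anilino ring would behave differently on the two cores. As far as these compounds go, each read-out comes from one concentration, and the effect at any other concentration also remains open.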